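Shortening a Side Chain in a Tail Flick Series

The source may hold more compounds than are shown below. What is called first, only, known or untested is meant among the compounds shown, and "the series" means these compounds.

Compound 1 `O=C(CN(c1ncnc2c1ncn2C1CCCCO1)C1CC1)N[C@@H](CCC(=O)OCc1ccccc1)C(=O)OCc1ccccc1` was tested in a functional assay on the whole organism (Tail, strain ICR) with Mus musculus as the target, in the tail flick test, with a stated time of 30 min, at a dose of 25 umol/kg by the oral route; on this read-out higher numbers stand for a stronger effect at the one dose given and lower numbers for a weaker effect; there compound 1 gives 32.6%. Among the compounds with values here, only one other number exists: compound 2 `CC(C)C[C@H](NC(=O)CN(c1nc(Cl)nc2[nH]cnc12)C1CC1)C(=O)OCc1ccccc1` gives 33.9%, and the two values lie within the usual scatter of each other, so neither stands apart. Compound 3 `CC(C)[C@H](NC(=O)CN(c1ncnc2c1ncn2C1CCCCO1)C1CC1)C(=O)OCc1ccccc1` has not been measured. It differs from compound 1 by isopropyl in place of 2-(benzyloxycarbonyl)ethyl on a saturated chain carbon bound to an amide-type nitrogen and a carbonyl carbon. Within the data shown here, no measured pair isolates such a change, so the step expected from compound 1 to compound 3 is a number 0.4 percentage points higher from compound 1 to compound 3 (within the scatter), a shift not beyond the scatter. Compound 3 is therefore estimated at 33%, ranging from 20% to 46%.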

Compound 3, a percentage reported as activity, at one dose (the size of the read-out at that dose, not a potency): 21.8%
Estimate against measurement, compound 3: 11.2 percentage points above, within the range that was stated.
By their numbers in this assay, from the lowest: compound 3; then compounds 1 and 2 (each within the scatter of the next).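

In this assay, isopropyl in place of 2-(benzyloxycarbonyl)ethyl gives a number 10.8 percentage points lower from compound 1 to compound 3 (beyond the scatter) and so shows that the group at this saturated chain carbon can change the read-out. The group that leaves carries both an aromatic ring and hydrogen-bond acceptors, and this single step cannot separate their contributions. Nothing shown gives a reason for the step. On these data alone, how a carboxylic acid, an amine or a longer plain carbon chain at this position would compare remains open. So does whether the step would be the same on another core.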